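The source may report more compounds than this note shows. Statements on the series, on what has been measured and on what is new or still open speak of the compounds shown alone.

Of the compounds shown here, three built on one shared core have been tested in an assay on microsomes from brain for inhibition of Fatty-acid amide hydrolase 1 (Rattus norvegicus), read by fluorescence and HPLC, with a stated time of 60 min; a higher number here means a weaker inhibitor, a lower number a stronger inhibitor. Compound 1 `CCCCCCCCc1ccc(OCC(=O)Cn2nnc(C)n2)cc1` carries a methyl group and gives 27 nM. Compound 2 `CCCCCCCCc1ccc(OCC(=O)Cn2nnc(-c3ccc(Cl)cc3)n2)cc1` carries a 4-chlorophenyl group in its place and gives 35 nM. Compound 3 `CCCCCCCCc1ccc(OCC(=O)Cn2nnc(-c3ccc(C(=O)OC)cc3)n2)cc1` carries a 4-(methoxycarbonyl)phenyl group and gives 29 nM. Compound 3 stands within the scatter of both of the others: the step is a 1.1-fold higher number from compound 1 to compound 3 (0.03 log units; within the scatter), and the step is a 1.2-fold lower number from compound 2 to compound 3 (0.08 log units; within the scatter). The step of a 1.3-fold higher number from compound 1 to compound 2 (0.11 log units; within the scatter) is likewise within the scatter, so the three numbers cannot be told apart.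

Compound 4 `CCCCCCCCc1ccc(OCC(=O)Cn2nnc(-c3ccc(S(=O)(=O)N(C)C)cc3)n2)cc1` has not yet been measured. It differs from compound 3 in one place: dimethylsulfamoyl in place of methoxycarbonyl on an aromatic carbon. Two of the steps seen bear on this change. Swapping chloro for methoxycarbonyl on an aromatic carbon gave a 1.2-fold lower number from compound 2 to compound 3 (0.08 log units; within the scatter), and swapping the small methyl for the whole substituted phenyl gave a 1.1-fold higher number from compound 1 to compound 3 (0.03 log units; within the scatter); neither moved the number beyond the scatter. The step expected here, a 1.0-fold higher number from compound 3 to compound 4 (0.01 log units; within the scatter), is accordingly none beyond the scatter. Compound 4 is estimated at 30 nM, with a range from 12 nM to 75 nM.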

Compound 4, half-maximal inhibitory concentration: 590 nM
Beside the measured number, compound 4's estimate is 20-fold (1.29 log units) below it; the whole stated range lies below it.
By their numbers in this assay, from the lowest: compounds 1, 3 and 2 (each within the scatter of the next); then compound 4.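

Within the data shown here, this place on the aromatic ring is less forgiving than the earlier compounds suggested. In this assay, dimethylsulfamoyl in place of methoxycarbonyl gives a 20-fold higher number from compound 3 to compound 4 (1.31 log units; beyond the scatter), dimethylsulfamoyl in place of chloro gives a 17-fold higher number from compound 2 to compound 4 (1.23 log units; beyond the scatter), and 4-(dimethylsulfamoyl)phenyl in place of methyl gives a 22-fold higher number from compound 1 to compound 4 (1.34 log units; beyond the scatter), so this group makes the inhibitor clearly weaker, whereas the three earlier groups could not be told apart. Nothing available explains this large step.

The compounds shown leave open whether the change depends on the sulfonyl part or on the two methyl groups on the nitrogen, which a plain sulfamoyl group or a methylsulfonyl group would help to separate. Going by these compounds, how an amine or a carboxylic acid at this place would behave also remains unknown.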